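Sulfonate ester series: acyl-to-urea change at the anilide

The source may hold more compounds than are shown below. What is called first, only, known or untested is meant among the compounds shown, and "the series" means these compounds.

Measured in a functional assay on HT-1080 cells (Homo sapiens) for antiproliferative activity, read by sulforhodamine B assay, with a stated time of 48 h; on this read-out higher numbers stand for weaker inhibition and lower numbers for stronger inhibition:
compound 1, `CC(=O)Nc1ccc(S(=O)(=O)Oc2ccccc2I)cc1`, 17000 nM
compound 2, `CCCC(=O)Nc1ccc(S(=O)(=O)Oc2ccccc2I)cc1`, 2000 nM
compound 3, `O=C(CCCl)Nc1ccc(S(=O)(=O)Oc2ccccc2I)cc1`, 4200 nM

Compound 3 holds the second highest of the three numbers in this assay. Its nearer neighbour is set by a 2.1-fold higher number from compound 2 to compound 3 (0.32 log units; beyond the scatter); the wider gap is set by a 4.0-fold lower number from compound 1 to compound 3 (0.61 log units; beyond the scatter). Both steps lie beyond the scatter, so compound 3 is clearly separated from each of the other two.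

Compound 4, `O=C(NCCCCl)Nc1ccc(S(=O)(=O)Oc2ccccc2I)cc1`, differs from compound 3 by (3-chloropropyl)amino in place of 2-chloroethyl on a carbonyl carbon. Among the measured compounds shown here, no measured step replaces the acyl side with a carbamoyl linkage, so that part of the change is untested. The steps that do bear on it concern the chain on the carbonyl carbon: an 8.5-fold lower number from compound 1 to compound 2 (0.93 log units; beyond the scatter) shows that lengthening the chain lowered the number, while a 2.1-fold higher number from compound 2 to compound 3 (0.32 log units; beyond the scatter) shows that a chlorine at the chain end, in place of methyl, raised it. Compound 4 carries a longer chain than compound 3 and still ends in chlorine, with the added amide-type nitrogen of unknown effect. The expectation is therefore a modest move to a lower number, with wide bounds: a 1.7-fold lower number from compound 3 to compound 4 (0.23 log units; within the scatter). Compound 4 is estimated at 2500 nM in this assay, within a range of 600 nM to 10000 nM.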

Compound 4, half-maximal inhibitory concentration: 2800 nM
Estimate against measurement, compound 4: 1.1-fold (0.05 log units) below; the range from low to high includes it.
By their numbers in this assay, from the lowest: compounds 2, 4 and 3 (each within the scatter of the next, the first and the last beyond it); then compound 1.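

In this assay, (3-chloropropyl)amino in place of 2-chloroethyl on a carbonyl carbon gives a 1.5-fold lower number from compound 3 to compound 4 (0.18 log units; within the scatter), so this position accepts the amide-type nitrogen and the longer chlorine-ended chain together without a step beyond the scatter. Set against propyl, the same group gives a 1.4-fold higher number from compound 2 to compound 4 (0.15 log units; within the scatter), and set against methyl it gives a 6.1-fold lower number from compound 1 to compound 4 (0.78 log units; beyond the scatter), which places compound 4 within the scatter of the two longer-chain compounds and clearly apart only from the acetyl end of the series. No measured property of these groups is at hand to account for the result.

The change alters the linkage and the chain at once, so the share of the amide-type nitrogen and the share of the extra chain length remain unseparated; (2-chloroethyl)amino or a chlorine-free propylamino on the same carbonyl carbon would pull them apart. Also open, on these data alone, is how this position responds to a longer chain, or to an amine or a carboxylic acid at the chain end in place of chlorine.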